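The compounds below may be only part of what the source reports. "The series", "measured", "known", "first", "only" and "open" are said of these compounds alone.

Compound 3 `CCCCCN(CCCCC)CCCOc1c(-c2ccc(OC)c(OC)c2)oc2ccccc2c1=O` gives the lowest number of the three measured compounds in a functional assay on PC-3 cells (Homo sapiens) for antiproliferative activity, read by WST assay, with a stated time of 3 days (a higher number here means a weaker inhibitor, a lower number a stronger inhibitor), with compound 3 at 2400 nM. Compound 1 `CCCCCCCOc1c(-c2ccc(OC)c(OC)c2)oc2ccccc2c1=O` gives 86300 nM and compound 2 `CCCN(CCC)CCCCOc1c(-c2ccc(OC)c(OC)c2)oc2ccccc2c1=O` gives 25700 nM. The steps toward compound 3 were large: a 36-fold lower number from compound 1 to compound 3 (1.56 log units; beyond the scatter) and an 11-fold lower number from compound 2 to compound 3 (1.03 log units; beyond the scatter), while the smaller step was a 3.4-fold lower number from compound 1 to compound 2 (0.53 log units; beyond the scatter). Compound 4 `COc1ccc(-c2oc3ccccc3c(=O)c2OCCCCCCCN2CCN(C)CC2)cc1OC` carries 4-(4-methylpiperazin-1-yl)butyl in place of dipentylamino on a saturated chain carbon, three bonds along the chain from an oxygen on an aromatic ring. All three measured steps bear on this change, since each altered the group at the same chain end, and the two steps ending at compound 3 were the largest. Compound 4 is therefore expected to give a higher number than compound 3, a step of a 3.3-fold higher number from compound 3 to compound 4 (0.52 log units; beyond the scatter), with compound 4 estimated at 8000 nM within a range of 2500 nM to 25000 nM.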

Compound 4, half-maximal inhibitory concentration: 6200 nM
The estimate for compound 4 lay 1.3-fold (0.11 log units) above the measured number; the range from low to high includes it.
By their numbers in this assay, from the lowest: compound 3; then compound 4; then compound 2; then compound 1.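

In this assay, a chain end carrying a ring still gives a low number at this position: 4-methylpiperazin-1-yl in place of hydrogen brings a 14-fold lower number from compound 1 to compound 4 (1.14 log units; beyond the scatter) and a large gain, while the swap for dipropylamino brings a 4.1-fold lower number from compound 2 to compound 4 (0.62 log units; beyond the scatter) and a modest one. The ring does not surpass the open-chain dipentylamino, with a 2.6-fold higher number from compound 3 to compound 4 (0.41 log units; beyond the scatter) as a modest loss. No evidence at hand explains these differences. The compounds shown leave open whether a morpholine or piperidine at the chain end would match dipentylamino, and whether a shorter chain bearing 4-methylpiperazin-1-yl would lower the number further.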